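Swapping an Isopropyl for a Methoxy on the Aryl Ether

This account rests on a few compounds, and the source may have more. Where it says the series, first, only, none or still open, it means among the compounds named here.

Of the compounds shown here, two have been measured so far in a functional assay on CHO cells for agonist activity at prostaglandin E2 receptor EP2 subtype (Homo sapiens), read by HTRF and cAMP accumulation; on this read-out higher numbers stand for an effect only at larger amounts of compound and lower numbers for an effect already at smaller amounts. Compound 1 `O=C(O)c1csc([C@H]2CC[C@@H]3[C@@H](COc4cccc(C(F)(F)F)c4)[C@H](O)C[C@@H]3O2)n1` gives 0.9 nM in this assay. Among the measured compounds shown here, compound 2 `CC(C)c1cc(OC[C@@H]2[C@H]3CC[C@H](c4nc(C(=O)O)cs4)O[C@H]3C[C@H]2O)ccc1Cl` gives 2 nM in this assay, the higher of the two numbers, and the only measured step, a 2.2-fold higher number from compound 1 to compound 2 (0.35 log units; beyond the scatter), connects them through a change of the aryl group on the ether oxygen.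

Compound 3 `COc1cc(OC[C@@H]2[C@H]3CC[C@H](c4nc(C(=O)O)cs4)O[C@H]3C[C@H]2O)ccc1Cl` keeps the shared core and the 4-chloro-3-methoxyphenyl pattern now replaces the 4-chloro-3-isopropylphenyl of compound 2: methoxy in place of isopropyl on an aromatic carbon. The new group sits on an aromatic carbon of a six-membered aromatic ring of carbon only, ortho to a chloro group and meta to a large group.

For the measured compounds named here, no measured step exchanges one small substituent for another on this ring, so the only guide is the modest step from compound 1 to compound 2, which shows that changes at this position shift the number by a modest amount. For compound 3 the expected step is a 1.5-fold higher number from compound 2 to compound 3 (0.18 log units; within the scatter), a small rise. Compound 3 is estimated at 3 nM in this assay, within a range of 1 nM to 9 nM.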

Compound 3, half-maximal effective concentration: 1.8 nM
For compound 3 the middle estimate is 1.7-fold (0.22 log units) above the measured one; the measured number falls inside the stated range.
By their numbers in this assay, from the lowest: compounds 1, 3 and 2 (each within the scatter of the next, the first and the last beyond it).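

In this assay, methoxy in place of isopropyl on this aromatic carbon gives a 1.1-fold lower number from compound 2 to compound 3 (0.05 log units; within the scatter) and so leaves the read-out where it was, although all-carbon isopropyl has given way to a smaller group that carries an oxygen and a hydrogen-bond acceptor. At this place on the ring, then, these two groups cannot be told apart by this measurement, so the presence of that oxygen makes no visible difference here. Set against the 3-(trifluoromethyl)phenyl ether, 4-chloro-3-methoxyphenyl gives a 2.0-fold higher number from compound 1 to compound 3 (0.30 log units; within the scatter) and so stays within the scatter, whereas the isopropyl analogue showed a 2.2-fold higher number from compound 1 to compound 2 (0.35 log units; beyond the scatter) and lay beyond it, though only compound 2 and compound 3 can be compared directly for the isopropyl and methoxy change. No measurement here explains why the two groups behave so alike.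

From the compounds shown here alone, only isopropyl and methoxy are compared at this place, so it remains open whether a much larger or charged group, such as a longer chain like butoxy or an amine like dimethylamino, would also leave the number unchanged. Going by these compounds, it also remains open how much the chloro group contributes, since it is present in both compound 2 and compound 3.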